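Swapping the Amide Aryl Group in a Quinoline Series

This account rests on a few compounds, and the source may have more. Where it says the series, first, only, none or still open, it means among the compounds named here.

The measured compounds in a functional assay on SK-BR-3 cells (Homo sapiens) for antiproliferative activity, read by MTT assay, with a stated time of 72 h (on this read-out higher numbers stand for weaker inhibition and lower numbers for stronger inhibition), are:
Compound 1, `CCN1CCN(c2cc(C)c3cc(NC(=O)c4cccc(Cl)c4)ccc3n2)CC1`, gives 17800 nM.
Compound 2, `CCc1ccccc1C(=O)Nc1ccc2nc(N3CCN(CC)CC3)cc(C)c2c1`, gives 23900 nM.
Compound 3, `Cc1cc(N2CCCCC2)nc2ccc(NC(=O)c3ccc(Cl)c(Cl)c3)cc12`, gives 42500 nM.

Compound 2 stands between compound 1 and compound 3 on these numbers, but all three lie within the usual scatter of one another, so no ranking among them can be read from this assay.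

The step of interest leads to compound 4, `CCN1CCN(c2cc(C)c3cc(NC(=O)c4cccc(F)c4)ccc3n2)CC1`, which is not yet measured. The change is 3-fluorophenyl in place of 2-ethylphenyl on a carbonyl carbon.

Among the compounds with values here, one measured step bears on this: a 1.3-fold higher number from compound 1 to compound 2 (0.13 log units; within the scatter), where one aryl group on the carbonyl carbon replaced another without a change beyond the scatter. Compound 4 carries a 3-fluorophenyl group, which is closer in kind to the 3-chlorophenyl of compound 1 than to the 2-ethylphenyl of compound 2, and compound 1 and compound 2 gave almost the same number. No step beyond the scatter is therefore expected: the estimated change is a 1.2-fold lower number from compound 2 to compound 4 (0.08 log units; within the scatter).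

Compound 4 is expected to give about 20000 nM in this assay, within a range of 8000 nM to 50000 nM.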

Compound 4, half-maximal inhibitory concentration: 24900 nM
Compound 4: middle estimate off by 1.2-fold (0.10 log units), on the low side; measured number inside the range.
By their numbers in this assay, from the lowest: compounds 1, 2, 4 and 3 (each within the scatter of the next, the first and the last beyond it).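

Compound 4 adds a third aryl group on the carbonyl carbon of the shared core, and in this assay replacing 2-ethylphenyl with 3-fluorophenyl gives a 1.0-fold higher number from compound 2 to compound 4 (0.02 log units; within the scatter) and so does not separate these two groups. Within the data shown here, it also gives the first comparison of two halogens at this place, where fluoro in place of chloro on an aromatic carbon gives a 1.4-fold higher number from compound 1 to compound 4 (0.15 log units; within the scatter) and so leaves no difference that can be read between them. Taken together, 3-chlorophenyl, 2-ethylphenyl and 3-fluorophenyl on this carbonyl carbon give numbers that this read-out cannot rank, and no available evidence offers an explanation for this.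

The compounds shown leave open whether an amine or a carboxylic acid on this aryl ring would give a step beyond the scatter. They also leave open how a longer chain in place of the ethyl group would read.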